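Shortening the ether chain from butoxy to methoxy

A few compounds are considered here, and "the series" means these few. Any claim that something is new, unique, unknown or untested is made for them only; others in the source may bear on it.

Of the compounds shown here, three sharing one core have been measured in a functional assay on HeLa cells (Homo sapiens) for antiproliferative activity, read by WST assay, with a stated time of 24 h (a higher number here means a weaker inhibitor, a lower number a stronger inhibitor), so far. Compound 1 (`C=C[C@]1(C)CC[C@@H](C(=C)CNC(C)(C)C)C[C@H]1C(=C)C`) carries a (tert-butyl)amino group and gives 25400 nM while the ethoxy compound 2 (`C=C[C@]1(C)CC[C@@H](C(=C)COCC)C[C@H]1C(=C)C`) gives 106000 nM and the butoxy compound 3 (`C=C[C@]1(C)CC[C@@H](C(=C)COCCCC)C[C@H]1C(=C)C`) gives 266000 nM as the highest number of the three. That makes compound 3 the weakest inhibitor of this small set. Replacing the amine gave a 4.2-fold higher number from compound 1 to compound 2 (0.62 log units; beyond the scatter) with ethoxy and a 10-fold higher number from compound 1 to compound 3 (1.02 log units; beyond the scatter) with butoxy, but these steps change the kind of group and say little about chain length.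

The next compound is compound 4 (`C=C[C@]1(C)CC[C@@H](C(=C)COC)C[C@H]1C(=C)C`), with hydrogen in place of propyl on a saturated chain carbon bound to an oxygen on a saturated carbon, which turns butoxy into methoxy (hydrogen in place of propyl on a saturated chain carbon bound to an oxygen on a saturated carbon). The closest guide is the pair of ethers, which showed a 2.5-fold higher number from compound 2 to compound 3 (0.40 log units; beyond the scatter) when ethyl replaced hydrogen on the chain. On these data alone, this trend rests on those two compounds alone, and methoxy itself is untested. Compound 4 loses more chain than that step added, so a somewhat larger step towards a lower number is expected. For compound 4 the expected change is a 4.0-fold lower number from compound 3 to compound 4 (0.60 log units; beyond the scatter) in this assay as an estimate. For compound 4 the estimated value is 67000 nM with an expected range from 30000 nM to 150000 nM as the likely span.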

Compound 4, half-maximal inhibitory concentration: 212000 nM
Beside the measured number, compound 4's estimate is 3.2-fold (0.50 log units) below it; the measured number lies above the stated range.
By their numbers in this assay, from the lowest: compound 1; then compounds 2, 4 and 3 (each within the scatter of the next, the first and the last beyond it).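

In this assay, methoxy and butoxy cannot be told apart at this place on the chain (a 1.3-fold lower number from compound 3 to compound 4 (0.10 log units; within the scatter)), and neither can methoxy and ethoxy (a 2.0-fold higher number from compound 2 to compound 4 (0.30 log units; within the scatter)). The short ether in compound 4 therefore does not extend the direction suggested by compound 2 and compound 3: chain length gives no steady trend across these three ethers, and only the ethoxy and butoxy pair lies beyond the scatter. Compound 4 still stands clearly apart from the amine (an 8.3-fold higher number from compound 1 to compound 4 (0.92 log units; beyond the scatter)), so compound 1, with its (tert-butyl)amino group, now has a lower number than all three ethers by more than the scatter, though nothing available here gives a reason for either finding.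

The compounds shown leave open whether this lower number belongs to amines in general or to (tert-butyl)amino in particular, which a simpler amine such as methylamino at the same place would help to settle. They also leave open whether a longer chain such as hexyloxy, or a hydroxyl group, would fall in the same range as the ethers.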